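From fluoro to methoxy on the shared core

The compounds below may be only part of what the source reports. "The series", "measured", "known", "first", "only" and "open" are said of these compounds alone.

Compound 3 `CSc1ccc(F)cc1NCC1=NCCN1` gives 115 nM in an assay on CHO cells for binding affinity to Alpha-2C adrenergic receptor (Homo sapiens), read by radioligand binding; a higher number here means a weaker inhibitor, a lower number a stronger inhibitor. Of the two numbers measured in this assay, compound 3 has the lowest; its nearest neighbour is compound 2 `CSc1ccc(C)cc1NCC1=NCCN1`, which gives 200 nM, and the step of a 1.7-fold lower number from compound 2 to compound 3 (0.24 log units; within the scatter) is within the scatter, so no order between the two can be claimed. Compound 1 `COc1ccc(S(C)(=O)=O)c(NCC2=NCCN2)c1` is reported in this assay only as a limit, < 5020 nM, and not as a number (the limit of < 5020 nM in this assay, at which 1 of the 3 values shown sits).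

Compound 4 `COc1ccc(SC)c(NCC2=NCCN2)c1` has not yet been measured. It differs from compound 3 in one place: methoxy in place of fluoro on an aromatic carbon. Within the data shown here, the only measured step that bears on this change is a 1.7-fold lower number from compound 2 to compound 3 (0.24 log units; within the scatter), an exchange of one small group for another on the same aromatic carbon, which left the number within the scatter. The change from compound 3 to compound 4 is another such exchange at that carbon, so a step in this assay that is small, with no clear direction beyond the scatter, is expected.

Compound 4 is therefore expected to give 150 nM in this assay, with a range from 50 nM to 500 nM. The expected step is a 1.3-fold higher number from compound 3 to compound 4 (0.12 log units; within the scatter).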

Compound 4, inhibition constant: 603 nM
Beside the measured number, compound 4's estimate is 4.0-fold (0.60 log units) below it; measured number above the stated range.
By their numbers in this assay, from the lowest: compounds 3 and 2 (each within the scatter of the next); then compound 4.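

Methoxy on this aromatic carbon, para to a methylsulfanyl group, produced a 5.2-fold higher number from compound 3 to compound 4 (0.72 log units; beyond the scatter) in this assay and is the first exchange at this position shown to move the number beyond the scatter, whereas a 1.7-fold lower number from compound 2 to compound 3 (0.24 log units; within the scatter) stayed within it. Measured against methyl the exchange points the same way, with a 3.0-fold higher number from compound 2 to compound 4 (0.48 log units; beyond the scatter) as its size, so fluoro and methyl cannot be told apart here while methoxy stands apart from both, and this carbon does not take every exchange of one group for another without a change in the number. No measurement shown gives a reason for this rise.

The step between compound 1 and compound 4 cannot be read, as compound 1 stands only as a limit. As far as these compounds go, it remains open whether the rise goes with the oxygen of methoxy or with its added carbon, and hydroxy, ethyl or an amine on this same carbon would be needed to separate the two.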